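Chloro to Methoxy: What Happens to the Maximal Response

The source may hold more compounds than are shown below. What is called first, only, known or untested is meant among the compounds shown, and "the series" means these compounds.

Compound 1 `O=C(O)Cc1sc(C(c2ccccc2)c2ccc(Cl)cc2)nc1-c1ccc(Cl)cc1` is one of three compounds that share a common core and have been tested in an in vitro functional assay on HEK285-7 cells for antagonist activity at prostaglandin D2 receptor 2 (Homo sapiens), read by BRET and beta-arrestin recruitment; on this read-out lower numbers stand for smaller maximal responses and higher numbers for larger maximal responses. In this assay compound 1 gives 80%. Compound 2 `O=C(O)Cc1sc(C(c2ccccc2)c2ccc(Cl)cc2)nc1-c1ccc(F)cc1` gives 80%, and compound 3 `CS(=O)(=O)Nc1cccc(-c2nc(C(c3ccc(F)cc3)c3ccc(F)cc3)sc2CC(=O)O)c1` gives 80%, so all three stand level within the usual scatter, and compound 1 cannot be set apart from either of them. Going by the values given here, the only step between two compounds that differ in a single place is no change at the digits printed from compound 1 to compound 2 (within the scatter), a swap of fluoro in place of chloro on an aromatic carbon, and it left the maximal response unchanged within the scatter.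

Compound 4 `COc1ccc(C(c2ccccc2)c2nc(-c3ccc(Cl)cc3)c(CC(=O)O)s2)cc1` has not yet been measured. Its difference from compound 1 is methoxy in place of chloro on an aromatic carbon, sitting para to a large group on a six-membered aromatic ring of carbon only. Among the compounds with values here, no measured step covers chloro giving way to methoxy at that place, so the expectation rests on the flat step no change at the digits printed from compound 1 to compound 2 (within the scatter) at the same position, which suggests that a change of the substituent there does not move the maximal response much. The step of a number 2 percentage points lower from compound 1 to compound 4 (within the scatter) is therefore expected to stay within the scatter. For compound 4 the estimate is 78%, with a range from 60% to 95%.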

Compound 4, largest response reached (reported as efficacy), in percent of the reference or control that the assay uses: 80%
Compound 4: middle estimate off by 2 percentage points, on the low side, and the stated range covers the measured number.
By their numbers in this assay, from the lowest: compounds 1, 2, 3 and 4 (each within the scatter of the next).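

In this assay, the new step is no change at the digits printed from compound 1 to compound 4 (within the scatter) and it replaces the chloro that compound 2 keeps, so it shows something the earlier pair could not, since compound 1 carries two chloro groups and only the other one had been changed. At this place, the maximal response therefore tolerates more than a swap of one halogen for another: the 4-chlorophenyl becomes a 4-methoxyphenyl, with two heavy atoms and one hydrogen-bond acceptor entering where one heavy atom and no acceptor leave. Nothing available explains why the response stays level across this change.

Going by these compounds, with all four compounds level, the set does not reveal any substituent that shifts the maximal response, so the limits of this tolerance remain unknown. An amine or a longer chain such as butoxy at the same place could hold the response level or move it, and the compounds shown cannot say which.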